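The compounds below may be only part of what the source reports. "The series", "measured", "known", "first", "only" and "open" are said of these compounds alone.

Measured compounds in an ADME assay on WI-38 cells (Homo sapiens) for cytotoxicity, read by sulforhodamine B assay, with a stated time of 24 h; on this read-out lower numbers stand for stronger inhibition and higher numbers for weaker inhibition:
compound 1, `O=C1Nc2ccc(S(=O)(=O)N3CCOCC3)cc2/C1=N/NS(=O)(=O)c1ccccc1`: 302000 nM
compound 2, `O=C1Nc2ccc(S(=O)(=O)N3CCOCC3)cc2/C1=N/c1ccc(O)cc1`: 259000 nM
compound 3, `O=C1Nc2ccc(S(=O)(=O)N3CCOCC3)cc2/C1=N/c1ccc(C(=O)O)cc1`: 313000 nM

All three compounds share one core and differ only in the group on the double-bonded nitrogen. On the numbers shown, compound 3 stands highest of the three, but neither gap to it is beyond the scatter: a 1.0-fold higher number from compound 1 to compound 3 (0.02 log units; within the scatter), and a 1.2-fold higher number from compound 2 to compound 3 (0.08 log units; within the scatter). The remaining pair is likewise flat, a 1.2-fold lower number from compound 1 to compound 2 (0.07 log units; within the scatter). None of the three can be told apart in this assay.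

Compound 4, `O=C1Nc2ccc(S(=O)(=O)N3CCOCC3)cc2/C1=N/c1ccc(Br)cc1`, differs from compound 3 in one place: bromo in place of carboxy on an aromatic carbon. Cut one bond further out, the change reads 4-carboxyphenyl to 4-bromophenyl. The step that bears most directly on it is the one at the same aromatic carbon, carboxy in place of hydroxy, which stayed within the scatter; the two steps exchanging the whole group on the double-bonded nitrogen also stayed within it. Bromo itself has not been measured in the series. With every shown step flat, no step beyond the scatter is expected in this assay for compound 4, the expected step being a 1.3-fold lower number from compound 3 to compound 4 (0.10 log units; within the scatter). Compound 4 is therefore estimated at 250000 nM, with a range from 100000 nM to 500000 nM.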

Compound 4, half-maximal inhibitory concentration: 372000 nM
For compound 4 the middle estimate is 1.5-fold (0.17 log units) below the measured one; low and high end bracket the measured number.
By their numbers in this assay, from the lowest: compounds 2, 1, 3 and 4 (each within the scatter of the next).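

Working notes on the series. In this assay, bromo on this aromatic carbon, para to a large group, gives no step beyond the scatter against either group already seen there: carboxy (a 1.2-fold higher number from compound 3 to compound 4 (0.07 log units; within the scatter)) and hydroxy (a 1.4-fold higher number from compound 2 to compound 4 (0.16 log units; within the scatter)). The exchange now covers a group with a hydrogen-bond donor and acceptor replaced by a single bromine atom with neither, and the number still stays within the scatter; the larger exchange on the double-bonded nitrogen, 4-bromophenyl in place of (phenylsulfonyl)amino, is flat as well (a 1.2-fold higher number from compound 1 to compound 4 (0.09 log units; within the scatter)). No supporting measurement is available to explain why these numbers stay together.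

Open, from the compounds shown here alone, is whether an amine, a methoxy group or a longer alkyl chain on this aromatic carbon would give any step beyond the scatter in this cell read-out. Also open is whether a change on the shared core, such as replacing the morpholine-bearing sulfonyl group with a simple amide, would move the number at all, since every change shown so far sits on the group carried by the double-bonded nitrogen.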